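This account rests on a few compounds, and the source may have more. Where it says the series, first, only, none or still open, it means among the compounds named here.

Measured in a functional assay on DU-145 cells (Homo sapiens) for cytotoxicity, read by MTT assay; a higher number here means a weaker inhibitor, a lower number a stronger inhibitor:
- compound 1 `CCCC(CC(=O)O[C@H](CC=C(C)C)C1=CC(=O)c2c(O)ccc(O)c2C1=O)OC(C)=O` gives 55700 nM
- compound 2 `CCC(CO[C@H](CC=C(C)C)C1=CC(=O)c2c(O)ccc(O)c2C1=O)OC(C)=O` gives 25400 nM
- compound 3 `CC(C)=CC[C@@H](OC(=O)CC(C)(O)c1ccccc1)C1=CC(=O)c2c(O)ccc(O)c2C1=O` gives > 100000 nM

Compound 3 has a limit of the assay and not a number, the case in the limit of > 100000 nM in this assay, at which 1 of the 3 values shown sits.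

Compound 4 `CC(C)=CC[C@@H](OC(=O)C1CCCOC1)C1=CC(=O)c2c(O)ccc(O)c2C1=O` is not yet measured. It carries oxan-3-yl in place of 2-hydroxy-2-phenylpropyl on a carbonyl carbon.

For the measured compounds named here, the one measured step that bears on this change is an at least 1.7-fold higher number from compound 1 to compound 3 (0.25 log units; that floor lies within the scatter). It gives only weak guidance, so the numbers of the neighbours serve as the anchor: compound 1 at 55700 nM and compound 2 at 25400 nM. In this assay the expected step is an at least 2.5-fold lower number from compound 3 to compound 4 (0.39 log units; beyond the scatter), towards a lower number. For compound 4 the estimate is 40000 nM, with an expected range of 15000 nM to 100000 nM.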

Compound 4, half-maximal inhibitory concentration: 29700 nM
Beside the measured number, compound 4's estimate is 1.3-fold (0.13 log units) above it, within the range that was stated.
By their numbers in this assay, from the lowest: compounds 2, 4 and 1 (each within the scatter of the next, the first and the last beyond it). At a limit, above all of these: compound 3.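

In this assay, compound 3 gives only a limit and not a number: the limit of > 100000 nM in this assay, at which 1 of the 4 values shown sits. On the carbonyl carbon, oxan-3-yl in place of 2-hydroxy-2-phenylpropyl brings the series back to a readable value, with a floor beyond the scatter (an at least 3.3-fold lower number from compound 3 to compound 4 (0.52 log units; beyond the scatter)). Compound 4 does not separate from the two acetoxy-bearing neighbours (a 1.2-fold higher number from compound 2 to compound 4 (0.07 log units; within the scatter) and a 1.9-fold lower number from compound 1 to compound 4 (0.27 log units; within the scatter)), so a non-aromatic ring fits here as the open chains do.

Open, from the compounds shown here alone, is whether the hydroxyl or the phenyl of 2-hydroxy-2-phenylpropyl sets the limit of compound 3, and whether the ring oxygen of oxan-3-yl counts. A cyclohexyl or piperidine ring on this carbonyl carbon lies outside the compounds shown.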